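The source may report more compounds than this note shows. Statements on the series, on what has been measured and on what is new or still open speak of the compounds shown alone.

Among the numbers in hand, compound 3 `COC(=O)Nc1cccc(-c2ccc(N(C)C)cc2)c1` stands lowest: in an assay on COS-7 cells for inhibition of patatin-like phospholipase domain-containing protein 2 (Mus musculus) (a higher number here means a weaker inhibitor, a lower number a stronger inhibitor), compound 3 gives 5000 nM. Compound 1 `CCOC(=O)c1cccc(-c2ccc(O)cc2)c1` lies beyond the scatter from it, since in this assay compound 1 gives 100000 nM. Compound 2 `CCOc1ccc(-c2ccccc2)cc1` reaches only a limit of this assay, at > 200000 nM. Compound 4 `CN(C)c1ccc(-c2cccc(NC(=O)C(C)(C)C)c2)cc1` differs from compound 3 in one place: tert-butyl in place of methoxy on a carbonyl carbon. For the measured compounds named here, no measured pair shows this exchange, so its effect rests on expectation alone. In this assay the step is expected to come out as a 1.6-fold higher number from compound 3 to compound 4 (0.20 log units; within the scatter), a modest weakening that may well fall within the scatter. Compound 4 is accordingly estimated at 8000 nM, with a range from 2000 nM to 30000 nM.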

Compound 4, half-maximal inhibitory concentration: > 200000 nM
Compound 4 ended at the assay's limit (the forecaster's own chance of this, stated with the estimate: 5%); middle value at least 25-fold (1.39 log units) away from the limit.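

For the compounds shown here, on a carbonyl carbon whose other neighbour is the amide-type nitrogen, the exchange gives the first single-place comparison here, and in this assay it reads an at least 40-fold higher number from compound 3 to compound 4 (1.60 log units; beyond the scatter). This place is therefore not indifferent to what it carries: methoxy keeps a measurable value, while tert-butyl does not. Compound 4 gives only a limit of the assay: the limit of > 200000 nM in this assay, at which 2 of the 4 values shown sit.

The compounds shown leave open whether the loss goes with the oxygen that leaves or with the carbons that enter. A methyl or an ethoxy on the same carbonyl carbon would separate the two.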